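This account rests on a few compounds, and the source may have more. Where it says the series, first, only, none or still open, it means among the compounds named here.

Measured so far in a functional assay on HL-60 cells (Homo sapiens) for cytotoxicity, read by WST assay, with a stated time of 48 h; on this read-out higher numbers stand for weaker inhibition and lower numbers for stronger inhibition:
- compound 1 `COC[C@H](C(C)C)C(c1ccc(O)c(OC)c1)c1ccc(O)c(OC)c1`: 72000 nM
- compound 2 `COc1cc(C(c2ccc(O)c(OC)c2)[C@@H](C)C(C)C)ccc1O`: 20000 nM

Of the two measured compounds, compound 2 holds the lower number in this assay, at 20000 nM, which makes it the stronger inhibitor of the pair. Compound 3 `COC[C@H](C)[C@@H](C)C(c1ccc(O)c(OC)c1)c1ccc(O)c(OC)c1` has not yet been measured. Its difference from compound 2 is 2-(methoxymethyl)-1-methylpropyl in place of 1,2-dimethylpropyl on a saturated chain carbon bound to two aromatic carbons.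

Among the compounds with values here, only one measured step bears on this change: a 3.6-fold lower number from compound 1 to compound 2 (0.56 log units; beyond the scatter). In that step, 1,2-dimethylpropyl replaces 1-(methoxymethyl)-2-methylpropyl at the same place. Within the data shown here, the group entering in compound 3 also holds a methoxymethyl, but it is a different group from the one in compound 1, so a single step is only a loose guide. A modest move towards higher numbers in this assay is expected, of similar or smaller size than that step. The estimated change is a 2.3-fold higher number from compound 2 to compound 3 (0.35 log units; beyond the scatter). For compound 3 the expected value is 45000 nM, with an estimated range of 18000 nM to 110000 nM.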

Compound 3, half-maximal inhibitory concentration: 68000 nM
Compound 3: the middle estimate sits 1.5-fold (0.18 log units) below what was measured; the measured number falls inside the stated range.
By their numbers in this assay, from the lowest: compound 2; then compounds 3 and 1 (each within the scatter of the next).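

In this assay, 2-(methoxymethyl)-1-methylpropyl in place of 1,2-dimethylpropyl on a saturated chain carbon bound to two aromatic carbons gives a 3.4-fold higher number from compound 2 to compound 3 (0.53 log units; beyond the scatter) and so confirms, with a second methoxymethyl-bearing group, the modest separation first seen in a 3.6-fold lower number from compound 1 to compound 2 (0.56 log units; beyond the scatter) for this place. The two methoxymethyl-bearing groups are not told apart in this read-out: a 1.1-fold lower number from compound 1 to compound 3 (0.02 log units; within the scatter) leaves 1-(methoxymethyl)-2-methylpropyl and 2-(methoxymethyl)-1-methylpropyl level, so among these three compounds only compound 2, the one without methoxymethyl, stands apart, and none goes against this. No measurement at hand accounts for the difference.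

The entering group in compound 3 differs from 1,2-dimethylpropyl both in heavy atoms and in its hydrogen-bond acceptor, so the compounds shown do not separate the effect of the added carbon from that of the added oxygen; a plain longer alkyl chain of the same size would bear on this. Also open, on these data alone, is how a hydroxymethyl or an aminomethyl group would read here in place of methoxymethyl, and whether anything at this place inhibits clearly more strongly than compound 2, which gives 20000 nM in this assay.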